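A few compounds are considered here, and "the series" means these few. Any claim that something is new, unique, unknown or untested is made for them only; others in the source may bear on it.

Measured so far in a functional assay on OVCAR-3 cells (Homo sapiens) for inhibition, read by MTT assay, with a stated time of 24 h; a lower number here means a stronger inhibitor, a higher number a weaker inhibitor:

- compound 1 `CC1(C)[C@H]2CC[C@]1(C)N(Cc1cn(-c3ccccc3Cl)nn1)C(=O)C2`: 40 nM
- compound 2 `CC1(C)[C@H]2CC[C@]1(C)N(Cc1cn(-c3ccc(O)cc3)nn1)C(=O)C2`: 410 nM
- compound 3 `Cc1ccc(-n2cc(CN3C(=O)C[C@@H]4CC[C@@]3(C)C4(C)C)nn2)cc1`: 40 nM

Not yet measured: compound 4 `CC1(C)[C@H]2CC[C@]1(C)N(Cc1cn(-c3ccc(Cl)cc3)nn1)C(=O)C2`

Compound 3, at 40 nM, stands level with compound 1, and together they hold the lowest number of the three. Compound 2 lies well apart from them at 410 nM. Compound 4 differs from compound 3 by chloro in place of methyl on an aromatic carbon, which is chloro in place of methyl on an aromatic carbon, or 4-methylphenyl to 4-chlorophenyl when cut one bond further out.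

Within the data shown here, three measured steps bear on this change. Compound 1, which carries a 2-chlorophenyl group, shows no change at the digits printed from compound 1 to compound 3 (within the scatter), so a chlorinated and a methylated phenyl have already given matching numbers. The two large steps both involve the 4-hydroxyphenyl group of compound 2, namely a 10-fold higher number from compound 1 to compound 2 (1.01 log units; beyond the scatter) and a 10-fold lower number from compound 2 to compound 3 (1.01 log units; beyond the scatter). Among the measured compounds shown here, no measured pair compares chloro with methyl at this place on the ring, so the evidence is indirect. In this assay, no step beyond the scatter is therefore expected. The expected outcome is a 1.1-fold higher number from compound 3 to compound 4 (0.05 log units; within the scatter). For compound 4 the estimated value is 45 nM, with an expected range from 18 nM to 120 nM.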

Compound 4, half-maximal inhibitory concentration: 160 nM
For compound 4 the middle estimate is 3.6-fold (0.55 log units) below the measured one, outside the stated range (above it).
By their numbers in this assay, from the lowest: compounds 1 and 3 (each within the scatter of the next); then compound 4; then compound 2.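

In this assay, chloro in place of methyl on the aromatic carbon para to a large group gives a 4.0-fold higher number from compound 3 to compound 4 (0.60 log units; beyond the scatter), so these two groups do not match at this place, although each counts as one heavy atom. The placing of the chlorine on the phenyl also counts: 4-chlorophenyl in place of 2-chlorophenyl gives a 4.0-fold higher number from compound 1 to compound 4 (0.60 log units; beyond the scatter), which means that the agreement between compound 1 and compound 3 does not carry over to a chloro and a methyl group at the same place. Hydroxy is not simply the one poor group here either, since chloro in place of hydroxy gives a 2.6-fold lower number from compound 2 to compound 4 (0.41 log units; beyond the scatter), which leaves compound 4 in a middle position, with compound 3 on one side and compound 2 on the other.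

Nothing available here accounts for these differences. It remains open how fluoro, bromo, methoxy, an amine or a carboxylic acid would compare with methyl, chloro and hydroxy at this place, and whether the order seen among these three groups would hold on another part of the phenyl ring.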